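A Methoxy Added to the Core of Compound 3

A few compounds are considered here, and "the series" means these few. Any claim that something is new, unique, unknown or untested is made for them only; others in the source may bear on it.

Of the compounds shown here, three have been measured in a functional assay for inhibition, with a stated time of 5 min, tested at 1 mM; on this read-out higher numbers stand for more inhibition at the one concentration tested (going by the name of the read-out) and lower numbers for less inhibition. Compound 1 `COc1ccc2[nH]cc(C(=O)/C(C#N)=C/C=C(\Cl)c3ccc(OC)c(OC)c3)c2c1` gives 58.2%, and compound 2 `COc1ccc2[nH]cc(C(=O)/C(C#N)=C/C=C(\Cl)c3ccc(Br)cc3)c2c1` gives 54.5%. Going by the values given here, the only single change among them is a number 3.7 percentage points lower from compound 1 to compound 2 (within the scatter). Compound 3 `COc1ccc(/C(Cl)=C/C=C(\C#N)C(=O)c2c[nH]c3ccccc23)cc1` gives 61.3%; its number is the largest of the three, yet it lies within the usual scatter of both compound 1 and compound 2, so its number cannot be called higher than theirs.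

Compound 4 `COc1ccc(/C(Cl)=C/C=C(\C#N)C(=O)c2c[nH]c3ccc(OC)cc23)cc1` has not yet been measured. It differs from compound 3 in one place: methoxy in place of hydrogen on an aromatic carbon. Among the compounds with values here, compound 1 and compound 2 already carry this methoxy on their core, but each of them also differs from compound 3 elsewhere, so no measured step isolates the methoxy alone. Within the data shown here, the one measured step, the exchange of the aryl group, stayed within the scatter, and the numbers of all three compounds sit close together. The expectation is therefore a step of a number 1.3 percentage points lower from compound 3 to compound 4 (within the scatter) in this assay, no larger than the scatter. Compound 4 is estimated at 60%, within a range from 45% to 75%.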

Compound 4, a percentage reported as inhibition, at one concentration (the size of the read-out at that concentration, not a potency): 60.7%
Estimate against measurement, compound 4: 0.7 percentage points below; low and high end bracket the measured number.
By their numbers in this assay, from the lowest: compounds 2, 1, 4 and 3 (each within the scatter of the next).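

In this assay, going by these compounds alone, the methoxy on the shared core can now be read alone for the first time: a step of a number 0.6 percentage points lower from compound 3 to compound 4 (within the scatter) shows that hydrogen and methoxy on this aromatic carbon cannot be told apart on this read-out. The new compound also gives two clean single changes on the other aromatic ring, a step of a number 6.2 percentage points higher from compound 2 to compound 4 (within the scatter) for methoxy in place of bromo and a step of a number 2.5 percentage points higher from compound 1 to compound 4 (within the scatter) for hydrogen in place of methoxy, and neither of these separates the groups compared either, so all three changes leave the number inside the usual spread of repeated measurements. No measurement at hand offers an explanation for these small steps.

From the compounds shown here alone, whether an amine, a carboxylic acid or a longer chain such as butoxy on the same core carbon would move the number beyond the scatter remains open. Also open, going by these compounds, is whether compounds that look alike in this assay would still look alike in a full potency measurement, given that this read-out reports one concentration only.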